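This account rests on a few compounds, and the source may have more. Where it says the series, first, only, none or still open, it means among the compounds named here.

Compound 1 (`CN(C)C(=O)N1Cc2ccccc2C(c2cccc(O)c2)C1`) and compound 2 (`CN(C)C(=O)N1Cc2cc(Cl)ccc2C(c2cccc(O)c2)C1`) share the same core and were both entered in a functional assay on A2780 cells (Homo sapiens) for antiproliferative activity; on this read-out lower numbers stand for stronger inhibition and higher numbers for weaker inhibition. There, compound 1 has the entry "not determined" (no result reported), while compound 2 gives 1190 nM. That makes compound 2 the only point of reference, with nothing to rank it against. Compound 3 (`CN(C)C(=O)N1Cc2c(ccc(Cl)c2Cl)C(c2cccc(O)c2)C1`) extends compound 2 by one change, chloro in place of hydrogen on an aromatic carbon, ortho to a chloro group. Within the data shown here, no measured pair shows what adding a chloro does in this assay, since compound 1 offers no number to compare with compound 2. Only a small step towards stronger inhibition is therefore expected, possibly no larger than the usual scatter. The estimated change is a 1.5-fold lower number from compound 2 to compound 3 (0.17 log units; within the scatter). For compound 3 the expected value is 800 nM, with an estimated range from 250 nM to 2500 nM.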

Compound 3, half-maximal inhibitory concentration: 3440 nM
Compound 3: middle estimate off by 4.3-fold (0.63 log units), on the low side, outside the stated range (above it).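

In this assay, among these compounds, placing a further chloro on this aromatic carbon, ortho to a chloro group and ortho to a fused ring, moves the result towards weaker inhibition, with a 2.9-fold higher number from compound 2 to compound 3 (0.46 log units; beyond the scatter) as the only step that can be read so far. It shows that this position of the shared core responds to the change, and that here the added chloro does not bring the stronger inhibition that compound 2 alone could not rule out. Nothing among the data shown explains why the number rises.

Going by these compounds, the effect of the chloro already present in compound 2 stays open: compound 1 gives "not determined" (no result reported) in this assay, so that step cannot be read. Also open, on these data alone, is whether a fluoro, a methoxy or an amine at this same position would shift the result in the same direction as chloro.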